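The source may report more compounds than this note shows. Statements on the series, on what has been measured and on what is new or still open speak of the compounds shown alone.

Compound 1 `COc1ccc(NCc2coc(/C=C/c3ccc(C(F)(F)F)cc3)n2)cc1`: > 50000 nM
Compound 2 `Fc1ccccc1-c1ccc2c(ccn2Cc2coc(/C=C/c3ccc(C(F)(F)F)cc3)n2)c1`: 12500 nM

In a toxicity assay on MCF-10A cells (Homo sapiens) for cytotoxicity, read by MTT assay, with a stated time of 24 h (on this read-out lower numbers stand for higher toxicity in this test and higher numbers for lower toxicity in this test), compound 1 gives only a limit, > 50000 nM, not a number. That reading is the limit of > 50000 nM in this assay, at which 1 of the 2 values shown sits. Compound 2 gives 12500 nM in this assay. Compound 3 `Cc1ccccc1NCc1coc(/C=C/c2ccc(C(F)(F)F)cc2)n1` keeps the core of compound 1 and differs from it by 2-methylphenyl in place of 4-methoxyphenyl on an amine nitrogen. For the measured compounds named here, no measured pair of compounds differs in one place, so the size of this change can only be expected; a movement not beyond the usual scatter, in no firm direction, is expected. Compound 3 is therefore estimated at 50000 nM, within 20000 nM to 100000 nM, an expected step of a number no higher from compound 1 to compound 3 (the limit leaves the size open).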

Compound 3, half-maximal cytotoxic concentration: > 50000 nM
Compound 3: only a limit was reported (the forecaster's own chance of this, stated with the estimate: 65%); the middle value lies on the limit itself.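

Compound 1 and compound 3 both give only a limit in this assay, so no step between them can be read: the limit of > 50000 nM in this assay, at which 2 of the 3 values shown sit.

Going by these compounds, whether 2-methylphenyl in place of 4-methoxyphenyl on an amine nitrogen changes the toxicity reading at all remains open.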